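Chloro to methoxy on the aryl ring: expected effect

The source may hold more compounds than are shown below. What is called first, only, known or untested is meant among the compounds shown, and "the series" means these compounds.

Compound 1 `CCOC(=O)/C=C1/SC(N2N=C(c3cc4ccccc4o3)CC2c2ccc(Cl)cc2)=NC1=O` gives a limit, > 5 ug/mL, in a functional assay on A549 cells (Homo sapiens) for antiproliferative activity, read by MTT assay, with a stated time of 96 h; a lower number here means a stronger inhibitor, a higher number a weaker inhibitor. Compound 2 `COC(=O)/C=C1/SC(N2N=C(c3cc4ccccc4o3)CC2c2ccc(Cl)cc2)=NC1=O` gives 1.08 ug/mL in this assay.

Within the data shown here, compound 2 holds the only actual number among the two values; the other value is a limit, namely (the limit of > 5 ug/mL in this assay, at which 1 of the 2 values shown sits). Among the measured compounds shown here, the one measured step, an at least 4.6-fold lower number from compound 1 to compound 2 (0.66 log units; beyond the scatter), changes the ester alkyl group and nothing on the aryl ring.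

Compound 3 `COC(=O)/C=C1/SC(N2N=C(c3cc4ccccc4o3)CC2c2ccc(OC)cc2)=NC1=O` differs from compound 2 by methoxy in place of chloro on an aromatic carbon. For the measured compounds named here, no measured step touches this aryl position, so the step from compound 1 to compound 2 gives no guidance on its size or direction, and nothing measured points to a change beyond the scatter in this assay.

Compound 3 is therefore estimated to give about 1.2 ug/mL in this assay, within a range of 0.4 ug/mL to 4 ug/mL. That estimate means an expected step of a 1.1-fold higher number from compound 2 to compound 3 (0.05 log units; within the scatter), which is within the scatter.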

Compound 3, half-maximal inhibitory concentration: 2.45 ug/mL
The estimate for compound 3 lay 2.0-fold (0.31 log units) below the measured number; the measured number falls inside the stated range.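

Replacing chloro with methoxy on the aromatic ring gives a 2.3-fold higher number from compound 2 to compound 3 (0.36 log units; beyond the scatter) in this assay, so the weaker result goes with the methoxy group. Among these compounds, this is the first measured sign that the group on this ring can shift the number, since the earlier step changed only the ester alkyl group. Nothing measured here accounts for the shift.

The compounds shown leave open how other groups at this place, such as an amine, a carboxylic acid or a longer alkoxy chain, would compare with chloro and methoxy. Going by these compounds, compound 1, with its ethyl ester, stands only at a limit, > 5 ug/mL, and how the same change from 4-chlorophenyl to 4-methoxyphenyl would act alongside that ester stays open.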